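From ethoxy to trifluoromethyl on compound 3

The source may report more compounds than this note shows. Statements on the series, on what has been measured and on what is new or still open speak of the compounds shown alone.

Values in a functional assay on MGC-803 cells (Homo sapiens) for inhibition, read by sulforhodamine B assay; a higher number here means a weaker inhibitor, a lower number a stronger inhibitor:
- Compound 1 `O=C1C=C(NC2CCCC2)C(=O)c2c1nc1n2[C@H]2OC[C@@H](O)[C@H]2OC1`: > 8000 nM, a limit of the assay
- Compound 2 `COc1ccccc1NC1=CC(=O)c2nc3n(c2C1=O)[C@H]1OC[C@@H](O)[C@H]1OC3`: 1630 nM
- Compound 3 `CCOc1ccc(NC2=CC(=O)c3nc4n(c3C2=O)[C@H]2OC[C@@H](O)[C@H]2OC4)cc1`: 1110 nM

Compound 3 has the lowest actual number, but it lies within the scatter of compound 2: a 1.5-fold lower number from compound 2 to compound 3 (0.17 log units; within the scatter). Its gain over the cyclopentyl amine is beyond the scatter: an at least 7.2-fold lower number from compound 1 to compound 3 (0.85 log units; beyond the scatter).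

Compound 4 `O=C1C=C(Nc2ccc(C(F)(F)F)cc2)C(=O)c2c1nc1n2[C@H]2OC[C@@H](O)[C@H]2OC1` has trifluoromethyl in place of ethoxy on an aromatic carbon. For the measured compounds named here, it keeps the phenyl ring on the amine, and the one step between phenyl groups stayed within the scatter. Going by the values given here, no measured compound carries trifluoromethyl, so the expected step in this assay is small, with no firm direction: a 1.3-fold higher number from compound 3 to compound 4 (0.10 log units; within the scatter). For compound 4 the estimated value is 1400 nM, with an expected range of 500 nM to 4500 nM.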

Compound 4, half-maximal inhibitory concentration: 2820 nM
For compound 4 the middle estimate is 2.0-fold (0.30 log units) below the measured one; low and high end bracket the measured number.
By their numbers in this assay, from the lowest: compounds 3, 2 and 4 (each within the scatter of the next, the first and the last beyond it). At a limit, above all of these: compound 1.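

Swapping only the group on the phenyl ring gives the first step between phenyl amines that lies beyond the scatter: a 2.5-fold higher number from compound 3 to compound 4 (0.40 log units; beyond the scatter). Replacing the whole 2-methoxyphenyl group gives no such separation: a 1.7-fold higher number from compound 2 to compound 4 (0.24 log units; within the scatter). The gain over the cyclopentyl amine survives the change, with an at least 2.8-fold lower number from compound 1 to compound 4 (0.45 log units; beyond the scatter), and that step rests on a limit: the limit of > 8000 nM in this assay, at which 1 of the 4 values shown sits.

This trend rests on a single pair of groups at this place. On these data alone, it remains open what a plain unsubstituted phenyl, a chlorine, a nitrile or an amine would give there.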